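Piperazine nitrogen substituent: butyl to 2-(dimethylamino)ethyl

A few compounds are considered here, and "the series" means these few. Any claim that something is new, unique, unknown or untested is made for them only; others in the source may bear on it.

Measured so far:
compound 1 `Cc1cccc2sc(NC(=O)CCN3CCN(C(C)C)CC3)nc12` — 1300 nM
compound 2 `CCCCN1CCN(CCC(=O)Nc2nc3c(C)cccc3s2)CC1` — 204 nM

In an assay on membranes from brain for displacement of a labelled ligand from Sigma non-opioid intracellular receptor 1 (Cavia porcellus), read by scintillation counting, with a stated time of 120 min (a lower number here means a stronger inhibitor, a higher number a weaker inhibitor), compound 2 gives 204 nM, the lower of the two numbers seen; compound 1 gives 1300 nM. Within the data shown here, the only step between measured compounds, a 6.4-fold lower number from compound 1 to compound 2 (0.80 log units; beyond the scatter), covers butyl in place of isopropyl on the amine nitrogen in the ring.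

Compound 3 `Cc1cccc2sc(NC(=O)CCN3CCN(CCN(C)C)CC3)nc12` differs from compound 2 by dimethylamino in place of ethyl on a saturated chain carbon, two bonds along the chain from an amine nitrogen in a ring. Read one bond further out, this is butyl to 2-(dimethylamino)ethyl, so the chain keeps its length and a dimethylamino takes the place of the terminal ethyl. Among the measured compounds shown here, no measured pair covers an added amine at this position; the step of a 6.4-fold lower number from compound 1 to compound 2 (0.80 log units; beyond the scatter) only shows that the identity of the group on this nitrogen matters at a modest size. With the chain length held, the change is expected to move the number little, with a slight lean toward a higher number given the absence of any measured step supporting the dimethylamino.

Compound 3 is estimated at 450 nM, range 150 nM to 1500 nM, a step of a 2.2-fold higher number from compound 2 to compound 3 (0.34 log units; beyond the scatter) expected from compound 2.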

Compound 3, inhibition constant: 1000 nM
Compound 3: middle estimate off by 2.2-fold (0.35 log units), on the low side; low and high end bracket the measured number.
By their numbers in this assay, from the lowest: compound 2; then compounds 3 and 1 (each within the scatter of the next).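

In this assay, the advantage seen with butyl does not carry over to a chain of the same length ending in an amine: a 4.9-fold higher number from compound 2 to compound 3 (0.69 log units; beyond the scatter), so dimethylamino in place of ethyl on a saturated chain carbon is enough on its own to produce a step beyond the scatter, and chain length alone does not set the number at this position. The comparison with isopropyl gives a 1.3-fold lower number from compound 1 to compound 3 (0.11 log units; within the scatter), so 2-(dimethylamino)ethyl and isopropyl cannot be told apart here, and among the three groups on this ring nitrogen, butyl alone stands out, making compound 2 the strongest of the three. No measurement at hand accounts for the step.

On these data alone, it remains open whether the step belongs to the nitrogen itself or to the two methyl groups on it, which a 2-methoxyethyl group or a plain pentyl chain would help to separate. Also open, as far as these compounds go, is whether compound 2, at 204 nM, sits at the best chain length, or whether a longer chain such as hexyl would give a lower number.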